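The source may report more compounds than this note shows. Statements on the series, on what has been measured and on what is new or still open speak of the compounds shown alone.

Compound 2 `CC(C)(C)C(=O)N1CCC(NCCSC(c2ccc(F)cc2)c2ccc(F)cc2)CC1` stands at the higher of the two numbers recorded so far in an assay on membranes from striatum (strain Sprague-Dawley) for displacement of a labelled ligand from sodium-dependent dopamine transporter (Rattus norvegicus), read by scintillation counting, with a stated time of 120 min; on this read-out higher numbers stand for weaker inhibition and lower numbers for stronger inhibition: compound 2 gives 352 nM, whereas compound 1 `O=C(c1ccccc1)N1CCC(NCCSC(c2ccc(F)cc2)c2ccc(F)cc2)CC1` gives 4.51 nM. Going by the values given here, the single change between them, a 78-fold higher number from compound 1 to compound 2 (1.89 log units; beyond the scatter), shows that the group carried on the carbonyl carbon weighs heavily in this assay. Compound 3 `Fc1ccc(C(SCCNC2CCN(CC3CC3)CC2)c2ccc(F)cc2)cc1` has not yet been measured; it differs from compound 2 by cyclopropylmethyl in place of (tert-butyl)carbonyl on an amine nitrogen in a ring, so the carbonyl is gone altogether and an alkyl group sits on the ring nitrogen instead. Among the compounds with values here, no measured step covers removal of the carbonyl, so the size of this step is uncertain; the one measured step only shows that this end of the molecule is sensitive to change. Because compound 2 sits at 352 nM, far weaker than compound 1, there is room for a lower number. The expected step is a 12-fold lower number from compound 2 to compound 3 (1.07 log units; beyond the scatter), toward stronger binding. Compound 3 is estimated at 30 nM, with a likely range from 5 nM to 200 nM.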

Compound 3, inhibition constant: 407 nM
The estimate for compound 3 lay 14-fold (1.13 log units) below the measured number, outside the stated range (above it).
By their numbers in this assay, from the lowest: compound 1; then compounds 2 and 3 (each within the scatter of the next).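

In this assay, a 1.2-fold higher number from compound 2 to compound 3 (0.06 log units; within the scatter), so on this ring nitrogen a cyclopropylmethyl group and a (tert-butyl)carbonyl group cannot be told apart, even though only the second carries a carbonyl. The carbonyl alone therefore does not account for the strong inhibition seen with benzoyl, and a 90-fold higher number from compound 1 to compound 3 (1.96 log units; beyond the scatter) shows that of the three groups, benzoyl alone stands apart from the others at this position. Nothing available here explains why these groups compare as they do.

From the compounds shown here alone, what remains open is whether the phenyl ring needs the carbonyl at all, a question that a benzyl group on this nitrogen would address. A cyclohexylcarbonyl group would likewise test whether the ring on the carbonyl carbon has to be aromatic.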